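Tert-butyl in Place of Phenyl: Expected Effect

A few compounds are considered here, and "the series" means these few. Any claim that something is new, unique, unknown or untested is made for them only; others in the source may bear on it.

Two compounds of the series carry a measurement in a functional assay on MCF7 cells (Homo sapiens) for inhibition, read by MTT assay, with a stated time of 72 h; on this read-out lower numbers stand for stronger inhibition of growth and higher numbers for weaker inhibition of growth. Compound 1 `O=S(=O)(NCCNCc1cccc2ccccc12)c1cc(C(F)(F)F)cc(C(F)(F)F)c1` gives 18000 nM. Compound 2 `O=S(=O)(NCCNCc1ccc(-c2ccccc2)cc1)c1cc(C(F)(F)F)cc(C(F)(F)F)c1` gives 1400 nM, the lowest of the two numbers; the gap between compound 2 and compound 1 lies beyond the usual scatter, so compound 2 is the more potent of the pair on what is shown.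

Compound 3 `CC(C)(C)c1ccc(CNCCNS(=O)(=O)c2cc(C(F)(F)F)cc(C(F)(F)F)c2)cc1` has not been measured in this assay. It differs from compound 2 in one place: tert-butyl in place of phenyl on an aromatic carbon. Within the data shown here, nothing measured so far isolates what this exchange does; the only comparison at hand, compound 1 against compound 2, changes a different part of the molecule.

Among the measured compounds shown here, with no measured step to lean on, the expectation for compound 3 is a small step, if any, in this assay: both groups at that position are carbon-only and of comparable size, so the estimate for the step from compound 2 to compound 3 is a 1.6-fold higher number from compound 2 to compound 3 (0.20 log units; within the scatter), close to no change beyond the scatter and leaning to a slightly higher number. Compound 3 is therefore estimated at 2200 nM, within a range from 700 nM to 7000 nM.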

Compound 3, concentration for 50% growth inhibition: 13000 nM
Compound 3: middle estimate off by 5.9-fold (0.77 log units), on the low side, outside the stated range (above it).
By their numbers in this assay, from the lowest: compound 2; then compounds 3 and 1 (each within the scatter of the next).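

In this assay this position proves sensitive to the exchange: tert-butyl in place of phenyl gives a 9.3-fold higher number from compound 2 to compound 3 (0.97 log units; beyond the scatter) and so marks the first measured effect at this place, even though both groups are carbon-only and neither has a hydrogen-bond donor or acceptor. Among these compounds, what the structures record as different is the loss of the aromatic ring and a smaller heavy-atom count, and the single step cannot separate these two changes. The step that swaps the whole naphthalen-1-yl group for 4-(tert-butyl)phenyl gives a 1.4-fold lower number from compound 1 to compound 3 (0.14 log units; within the scatter) and leaves compound 3 and compound 1 indistinguishable in this read-out, while no measurement to hand accounts for the effect of the exchange at this position.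

Open, going by these compounds, is whether an aromatic ring at this place is what matters, or ring size alone: a cyclohexyl group or a pyridyl ring there would begin to separate these possibilities. Also open, on these data alone, is how the read-out responds to a substituent on that phenyl, such as a carboxylic acid or an amine.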